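Free fraction notes: piperidin-1-yl to isopropoxy

The source may report more compounds than this note shows. Statements on the series, on what has been measured and on what is new or still open speak of the compounds shown alone.

Measured so far in an ADME assay on a cell-free system (plasma, Homo sapiens) (on this read-out lower numbers stand for a smaller free fraction and higher numbers for a larger free fraction), are two compounds:
- compound 1 `CCc1c(CCCC(=O)O)cncc1-c1nsc(-c2ccc(CC(C)C)c(C#N)c2)n1` gives 0.0014 here
- compound 2 `CCc1c(CCCC(=O)O)cccc1-c1nsc(-c2ccc(N3CCCCC3)c(C(F)(F)F)c2)n1` gives 0.00001 here

Compound 2 holds the lowest of the two numbers, and the gap up to compound 1 lies beyond the scatter. Compound 3 `CCc1c(CCCC(=O)O)cccc1-c1nsc(-c2ccc(OC(C)C)c(C(F)(F)F)c2)n1` follows from compound 2 by one change (isopropoxy in place of piperidin-1-yl on an aromatic carbon), isopropoxy in place of piperidin-1-yl on an aromatic carbon. For the measured compounds named here, no measured pair isolates this change, so the expectation is tentative. The expected 10-fold higher number from compound 2 to compound 3 (1.00 log units; beyond the scatter) is a rise beyond the scatter, toward compound 1. Compound 3 is estimated at 0.0001 (range 0.00002 to 0.0005).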

Compound 3, unbound fraction: 0.00014
For compound 3 the middle estimate is 1.4-fold (0.15 log units) below the measured one; measured number inside the range.
By their numbers in this assay, from the lowest: compound 2; then compound 3; then compound 1.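

In this assay, the aromatic carbon para to a large group and ortho to a trifluoromethyl group proves sensitive to its substituent: isopropoxy in place of piperidin-1-yl gives a 14-fold higher number from compound 2 to compound 3 (1.15 log units; beyond the scatter). For the compounds shown here, this is the only single-place step, so the change alone moves the free fraction beyond the scatter. Nothing available bears on the cause of this step.

Open, as far as these compounds go, is whether the step follows the ring or the linking atom; diethylamino or cyclohexyloxy at this position would separate them. Also open, from the compounds shown here alone, is whether it persists with a nitrile in place of trifluoromethyl.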